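This account rests on a few compounds, and the source may have more. Where it says the series, first, only, none or still open, it means among the compounds named here.

In an ADME assay on BCBL1 cells (Homo sapiens) for cytotoxicity, with a stated time of 7 days (a higher number here means that more compound is tolerated, a lower number that less compound is tolerated), compound 1 `CNc1nc(N)nc2c1ncn2/C=C1/CC1(CO)CO` gives a measured 67000 nM. Compound 2 `Nc1nc(SC2CCCC2)c2ncn(/C=C3/CC3(CO)CO)c2n1` is reported only as a limit, > 20000 nM. Compound 3 `CCCCNc1nc(N)nc2c1ncn2/C=C1/CC1(CO)CO` is also reported only as a limit, > 20000 nM, so it has no exact place on the scale. Much of the picture therefore rests on (the limit of > 20000 nM in this assay, at which 2 of the 3 values shown sit).

Compound 4 `Nc1nc(SCc2ccccc2)c2ncn(/C=C3/CC3(CO)CO)c2n1` has benzylsulfanyl in place of butylamino on an aromatic carbon, and the counted difference is benzylsulfanyl in place of butylamino on an aromatic carbon. The closest measured comparison is a step that the two limits leave unreadable from compound 2 to compound 3, where butylamino replaces cyclopentylsulfanyl at the same place. The other two comparisons are a step that the limit leaves unreadable from compound 1 to compound 2 and a step that the limit leaves unreadable from compound 1 to compound 3. Going by the values given here, none of these gives a size that can be carried over to the new change, so the data offer no measured step to rely on.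

The nearest guide is a single reading. Like compound 4, compound 2 carries a sulfanyl group on that aromatic carbon, and it sits at > 20000 nM, again a limit. The expected change is a step that the limit leaves unreadable from compound 3 to compound 4, and the data fix no direction for it. Compound 4 may well be reported only as a limit too. For compound 4, the estimated value is 30000 nM, with an expected range from 10000 nM to 90000 nM.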

Compound 4, half-maximal cytotoxic concentration: > 20000 nM
Compound 4 ended at the assay's limit; the forecaster's own chance of this, stated with the estimate: 70%; the middle value is on the limit's open side.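

In this assay compound 4 is reported only as a limit (> 20000 nM), so its steps to compound 1, compound 2 and compound 3 cannot be read. Still open is how far compound 2, compound 3 and compound 4 truly lie from one another and from compound 1, with most of the picture resting on one point: the limit of > 20000 nM in this assay, at which 3 of the 4 values shown sit.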